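Trifluoromethyl added to the ring-bound phenyl of compound 2

The source may hold more compounds than are shown below. What is called first, only, known or untested is meant among the compounds shown, and "the series" means these compounds.

Measured so far:
compound 1 `COc1cc(/C=C/C(=O)OCCSc2nc(-c3ccc(S(C)(=O)=O)cc3)n(-c3ccc(C(F)(F)F)cc3)n2)ccc1OC(C)=O` gives 920 nM
compound 2 `COc1cc(/C=C/C(=O)OCCSc2nc(-c3ccc(S(C)(=O)=O)cc3)n(-c3ccccc3)n2)ccc1O` gives 840 nM

Both numbers come from an assay on cells (strain Sprague-Dawley) for inhibition of Polyunsaturated fatty acid 5-lipoxygenase (Rattus norvegicus), with a stated time of 30 min; a higher number here means a weaker inhibitor, a lower number a stronger inhibitor. Compound 2 `COc1cc(/C=C/C(=O)OCCSc2nc(-c3ccc(S(C)(=O)=O)cc3)n(-c3ccccc3)n2)ccc1O` has the lowest of the two numbers, but its nearest neighbour is compound 1 `COc1cc(/C=C/C(=O)OCCSc2nc(-c3ccc(S(C)(=O)=O)cc3)n(-c3ccc(C(F)(F)F)cc3)n2)ccc1OC(C)=O`, whose value in this assay sits within the usual scatter of that of compound 2, so the two cannot be told apart on these data.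

Compound 3 `COc1cc(/C=C/C(=O)OCCSc2nc(-c3ccc(S(C)(=O)=O)cc3)n(-c3ccc(C(F)(F)F)cc3)n2)ccc1O` has not yet been measured. It differs from compound 2 in one place: trifluoromethyl in place of hydrogen on an aromatic carbon, para to a large group. Cut one bond further out, the change reads phenyl to 4-(trifluoromethyl)phenyl. Among the compounds with values here, no pair of measured compounds shows this change on its own, so its effect in this assay is unknown here. Within the data shown here, the only guide is that compound 1, which carries the same trifluoromethyl group together with a further change elsewhere, gives 920 nM, close to compound 2.

Compound 3 is therefore expected to stay near compound 2, with a step of a 1.0-fold higher number from compound 2 to compound 3 (0.02 log units; within the scatter) that does not reach beyond the scatter. The estimate for compound 3 in this assay is 880 nM, with a range from 400 nM to 1900 nM.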

Compound 3, half-maximal inhibitory concentration: 810 nM
The estimate for compound 3 lay 1.1-fold (0.04 log units) above the measured number; the range from low to high includes it.
By their numbers in this assay, from the lowest: compounds 3, 2 and 1 (each within the scatter of the next).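

In this assay, trifluoromethyl in place of hydrogen on an aromatic carbon, para to a large group, is now seen on its own, and it gives a 1.0-fold lower number from compound 2 to compound 3 (0.02 log units; within the scatter) with nothing else altered, so phenyl and 4-(trifluoromethyl)phenyl cannot be told apart at this position. The same compound isolates the other difference carried by compound 1: hydrogen in place of acetyl on the oxygen on an aromatic ring gives a 1.1-fold lower number from compound 1 to compound 3 (0.06 log units; within the scatter) and so also stays within the usual scatter. Within the data shown here, each of the two single changes can therefore be read separately for the first time, and the closeness of compound 1 to compound 2 is not the sum of two steps that are each large and opposite.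

Only hydrogen and trifluoromethyl are shown at this position on the phenyl ring, so it remains open whether a group of another kind there, such as an amine, a carboxylic acid or a longer chain, would also leave the number unmoved. No other measurement is available to explain why these two changes leave the values so close.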